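Moving One Fluorinated Group and Swapping Another

The source may report more compounds than this note shows. Statements on the series, on what has been measured and on what is new or still open speak of the compounds shown alone.

Of the compounds shown here, three have been tested in a functional assay on CWR22R cells (Homo sapiens) for antiproliferative activity, read by propidium iodide staining, with a stated time of 96 h (on this read-out lower numbers stand for stronger inhibition and higher numbers for weaker inhibition), and a fourth awaits its result. Compound 1 `CC(O)(CSc1ccc(F)cc1)C(=O)Nc1ccc(S(F)(F)(F)(F)F)cc1` gives 13500 nM in this assay. Compound 2 `CC(O)(CSc1ccc(C(F)(F)F)cc1)C(=O)Nc1ccc(S(F)(F)(F)(F)F)cc1` differs from compound 1 by a single change, (trifluoromethyl in place of fluoro on an aromatic carbon), and in this assay compound 2 gives 14800 nM; the step of a 1.1-fold higher number from compound 1 to compound 2 (0.04 log units; within the scatter) is too small to be called a real change. Compound 3 `CC(O)(CSc1ccc(F)cc1)C(=O)Nc1cccc(S(F)(F)(F)(F)F)c1` has the same atoms as compound 1 joined differently; the difference between the two cores is not broken down here. In this assay compound 3 gives 30200 nM, the highest of the three numbers and beyond the scatter from both compound 1 and compound 2.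

Compound 4 `CC(O)(CSc1ccc(C(F)(F)F)cc1)C(=O)Nc1cccc(S(F)(F)(F)(F)F)c1` stands to compound 3 as compound 2 stands to compound 1: the change is trifluoromethyl in place of fluoro on an aromatic carbon, made on the core of compound 3 rather than that of compound 1. This is the same change seen between compound 1 and compound 2, made at the same place on the ring. Because that earlier step was a 1.1-fold higher number from compound 1 to compound 2 (0.04 log units; within the scatter), the step from compound 3 to compound 4 is expected to be of much the same small size, a 1.1-fold higher number from compound 3 to compound 4 (0.03 log units; within the scatter), though the core it is made on is different. Compound 4 is therefore estimated at 32000 nM in this assay, with a likely range of 15000 nM to 68000 nM.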

Compound 4, half-maximal inhibitory concentration: 26900 nM
Beside the measured number, compound 4's estimate is 1.2-fold (0.08 log units) above it, and the stated range covers the measured number.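

In this assay, putting trifluoromethyl in place of fluoro gives a 1.1-fold lower number from compound 3 to compound 4 (0.05 log units; within the scatter), a shift small enough to be ordinary variation between repeat measurements rather than a real effect of the swap. Setting this beside the same swap on the other core shows that the two results agree: the same change on two cores in this assay, a 1.1-fold higher number (0.04 log units; within the scatter) from compound 1 to compound 2 and a 1.1-fold lower number (0.05 log units; within the scatter) from compound 3 to compound 4, 1.2-fold (0.09 log units) apart, within the scatter of two such steps Within these two cores, then, the change carries over in the sense that it leaves the number essentially unmoved on both, so a result on one core would have served as a fair guide to the other, but this is agreement between two steps that are both indistinguishable from no change, not a clear effect seen twice, and it says nothing about other cores, other assays or why the swap makes so little difference.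

The compounds shown carry only fluoro or trifluoromethyl on this aromatic carbon, which leaves open what a nitrile, a methoxy group or a carboxylic acid would do in the same place. Also open, as far as these compounds go, is how the number would respond if the sulfur link were replaced by a sulfonyl group or the hydroxyl group by an amine, on either core.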